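The compounds below may be only part of what the source reports. "The series", "measured", "known", "first", "only" and "open" are said of these compounds alone.

Going by the values given here, compound 1 `O=C1O[C@H]([C@@H](O)Cn2cc(CNS(=O)(=O)c3ccc(Cl)cc3)nn2)C(OCc2ccccc2)=C1OCc1ccccc1` is the only member of this small set that gives a number in a functional assay on HCT-116 cells (Homo sapiens) for antiproliferative activity, read by MTT assay, with a stated time of 72 h; on this read-out lower numbers stand for stronger inhibition and higher numbers for weaker inhibition: in this assay compound 1 gives 8380 nM. Compound 2 `COc1ccc(-c2cn(C[C@H](O)[C@H]3OC(=O)C(OCc4ccccc4)=C3OCc3ccccc3)nn2)cc1` reaches only a limit of the assay, > 100000 nM. Among the compounds with values here, the one measured step, an at least 11-fold higher number from compound 1 to compound 2 (1.07 log units; beyond the scatter), swaps the whole (((4-chlorophenyl)sulfonyl)amino)methyl for a 4-methoxyphenyl, and its size is set by the limit of > 100000 nM in this assay, at which 1 of the 2 values shown sits, rather than by two measured numbers. Compound 3 `O=C1O[C@H]([C@@H](O)Cn2cc(CNS(=O)(=O)c3ccc(Cl)cc3F)nn2)C(OCc2ccccc2)=C1OCc1ccccc1` keeps the arm of compound 1 intact and differs from it by fluoro in place of hydrogen on an aromatic carbon of a six-membered aromatic ring of carbon only, ortho to a large group and meta to a chloro group, so that 4-chlorophenyl becomes 4-chloro-2-fluorophenyl. Within the data shown here, no measured step bears on a change of this kind; the step from compound 1 to compound 2 concerns a far larger rebuilding. For compound 3 the expected step in this assay, a 1.0-fold lower number from compound 1 to compound 3 (0.02 log units; within the scatter), is therefore none beyond the scatter. Compound 3 is estimated at 8000 nM, in a range from 3000 nM to 22000 nM.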

Compound 3, half-maximal inhibitory concentration: 21600 nM
For compound 3 the middle estimate is 2.7-fold (0.43 log units) below the measured one, and the stated range covers the measured number.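

In this assay, the ((4-chlorophenyl)sulfonyl)amino arm of compound 1 turns out to respond to a single added atom: fluoro in place of hydrogen on an aromatic carbon, ortho to a large group and meta to a chloro group, gives a 2.6-fold higher number from compound 1 to compound 3 (0.41 log units; beyond the scatter), a modest weakening but one that lies beyond the scatter. The earlier step replaced the whole arm and its size rested on a limit, whereas this one joins two measured numbers and shows that this single carbon of the 4-chlorophenyl ring is not indifferent to substitution. Nothing shown here gives a reason for this weakening.

As far as these compounds go, what a methyl or methoxy group on this same carbon would do remains open, as does the effect of fluoro on the other carbons of the ring, so the step cannot yet be assigned to fluoro itself or to any substituent at this place. Also open, from the compounds shown here alone, is what an amine in place of the hydroxy group on the chain would do to the activity of the shared core.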